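Chloro to methyl on the sulfonamide aryl ring

This account rests on a few compounds, and the source may have more. Where it says the series, first, only, none or still open, it means among the compounds named here.

Compound 2 `O=C1O[C@H]([C@@H](O)Cn2cc(CNS(=O)(=O)c3ccc(Cl)cc3)nn2)C(OCc2ccccc2)=C1OCc1ccccc1` gives 18000 nM in a functional assay on SW-620 cells (Homo sapiens) for antiproliferative activity, read by MTT assay, with a stated time of 72 h (a lower number here means a stronger inhibitor, a higher number a weaker inhibitor), and stands at the upper end of the two measured numbers, separated from compound 1 `CCCCCc1ccc(-c2cn(C[C@H](O)[C@H]3OC(=O)C(OCc4ccccc4)=C3OCc3ccccc3)nn2)cc1` only by a 1.5-fold higher number from compound 1 to compound 2 (0.17 log units; within the scatter). In this assay compound 1 gives 12200 nM. Compound 3 `Cc1ccc(S(=O)(=O)NCc2cn(C[C@H](O)[C@H]3OC(=O)C(OCc4ccccc4)=C3OCc3ccccc3)nn2)cc1` differs from compound 2 by methyl in place of chloro on an aromatic carbon. Going by the values given here, the single measured step exchanges the whole arm carried on the aromatic carbon of the shared core, not a substituent on the sulfonyl-bearing phenyl, so no measured pair bears directly on the change from compound 2 to compound 3. With nothing in the data pointing in either direction, no shift beyond the scatter is expected in this assay. Compound 3 is therefore estimated at 18000 nM, with a range from 8000 nM to 40000 nM. The expected step of no change at the digits printed from compound 2 to compound 3 (within the scatter) is thus one that stays within the scatter.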

Compound 3, half-maximal inhibitory concentration: 45800 nM
For compound 3 the middle estimate is 2.5-fold (0.41 log units) below the measured one; measured number outside the range, above it.
By their numbers in this assay, from the lowest: compounds 1 and 2 (each within the scatter of the next); then compound 3.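

In this assay the aromatic carbon para to a large group turns out to respond to its substituent: methyl in place of chloro, one heavy atom for another, gives a 2.5-fold higher number from compound 2 to compound 3 (0.41 log units; beyond the scatter) and leaves compound 3 as the weakest inhibitor of the three. The arm exchange also reads differently now, since the (((4-methylphenyl)sulfonyl)amino)methyl arm in place of 4-pentylphenyl gives a 3.8-fold higher number from compound 1 to compound 3 (0.57 log units; beyond the scatter) while the chloro counterpart in compound 2 stays within the scatter of compound 1. Nothing available accounts for the loss on going to methyl.

This position is described by chloro and methyl alone, a single pair that fixes no wider order among substituents. On these data alone, whether fluoro, methoxy, an amine or a carboxylic acid on this carbon would track either compound remains open.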